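Sulfonyl Aryl Variation on a Shared Indazole-Free Core Scaffold

This account rests on a few compounds, and the source may have more. Where it says the series, first, only, none or still open, it means among the compounds named here.

Measured compounds:
- Compound 1, `COc1ccc(S(=O)(=O)c2n[nH]c3ccc(N4CCN(C)CC4)cc23)cc1`: 12 nM
- Compound 2, `CN1CCN(c2ccc3[nH]nc(S(=O)(=O)c4cccs4)c3c2)CC1`: 7.8 nM

Compound 2 stands at the lowest of the two numbers in an assay on HeLa cells for displacement of a labelled ligand from 5-hydroxytryptamine receptor 6 (Homo sapiens); a higher number here means a weaker inhibitor, a lower number a stronger inhibitor; its nearest neighbour is compound 1, and the step of a 1.5-fold lower number from compound 1 to compound 2 (0.19 log units; within the scatter) lies within the scatter, so the two cannot be ordered against each other on these numbers.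

The next compound, compound 3, `COc1cccc(S(=O)(=O)c2n[nH]c3ccc(N4CCN(C)CC4)cc23)c1`, has not yet been measured. Its change from compound 2 is 3-methoxyphenyl in place of thiophen-2-yl on a sulfonyl sulfur. Among the compounds with values here, the only measured step that bears on this position is a 1.5-fold lower number from compound 1 to compound 2 (0.19 log units; within the scatter), which swapped a methoxyphenyl for a thiophenyl on the same sulfonyl sulfur and moved the number by less than the scatter. Within the data shown here, compound 3 returns to a methoxyphenyl group, differing from compound 1 only in where the methoxy sits on the ring, for which no measured step exists.

He therefore expects no step beyond the scatter for compound 3, roughly a 1.5-fold higher number from compound 2 to compound 3 (0.19 log units; within the scatter), because the related step of a 1.5-fold lower number from compound 1 to compound 2 (0.19 log units; within the scatter) was itself small. Compound 3 is estimated at 12 nM in this assay, with a range from 5 nM to 30 nM.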

Compound 3, inhibition constant: 1.1 nM
Compound 3: the middle estimate sits 11-fold (1.04 log units) above what was measured; measured number below the stated range.
By their numbers in this assay, from the lowest: compound 3; then compounds 2 and 1 (each within the scatter of the next).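

In this assay this position proves more sensitive than the earlier pair suggested: that pair's exchange of 4-methoxyphenyl for thiophen-2-yl on a sulfonyl sulfur, a 1.5-fold lower number from compound 1 to compound 2 (0.19 log units; within the scatter), stayed within the scatter, whereas the exchange of thiophen-2-yl for 3-methoxyphenyl gives a 7.1-fold lower number from compound 2 to compound 3 (0.85 log units; beyond the scatter). The clearest new information comes from the two methoxyphenyl compounds, where moving from 4-methoxyphenyl to 3-methoxyphenyl gives an 11-fold lower number from compound 1 to compound 3 (1.04 log units; beyond the scatter) and shows that these isomeric groups are not interchangeable here. Compound 3 therefore has the lowest number of the three, with its steps to both other compounds printed as beyond the scatter.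

The compounds shown leave open whether this lower number depends on the methoxy group itself or would persist with a hydroxyl, an amine or a longer ether chain in its place on the phenyl ring. They also leave open whether the step would keep its size if the methylpiperazine on the shared core gave way to another amine. No supporting measurement accompanies these compounds to explain the difference between the two methoxyphenyl groups.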